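The source may report more compounds than this note shows. Statements on the series, on what has been measured and on what is new or still open speak of the compounds shown alone.

Measured compounds, with their values in an assay on membranes from HEK293 cells for displacement of a labelled ligand from adenosine receptor A2b (Homo sapiens), read by scintillation counting, with a stated time of 30 min, tested at 1 uM; a higher number here means more inhibition at the concentration tested (going by the name of the read-out), a lower number less inhibition:

- compound 1 `COC(=O)C1=C(C)NC(=O)NC1c1ccoc1` gives 42%
- compound 2 `COC(=O)C1=C(C)NC(=O)NC1c1cccs1` gives 19%
- compound 3 `COC(=O)C1=C(C)NC(=S)NC1c1ccoc1` gives 48%

Compound 4 `COC(=O)C1=C(C)NC(=S)NC1c1cccs1` has not yet been measured. Compound 3 and compound 1 share most of their structure, but how their two cores differ is not broken down here; their values in this assay lie within the scatter of each other. Compound 4 differs from compound 3 by one change, (thiophen-2-yl in place of furan-3-yl on a saturated ring carbon). The same change, (thiophen-2-yl in place of furan-3-yl on a saturated ring carbon), has already been made once, and there it gave a number 23 percentage points lower from compound 1 to compound 2 (beyond the scatter). Since the place of the change is the same in both pairs, a step of similar size is expected in this assay, namely a number 23 percentage points lower from compound 3 to compound 4 (beyond the scatter), resting on that one earlier step from compound 1 to compound 2. Compound 4 is therefore estimated at 25%, with a likely range from 10% to 40%.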

Compound 4, a percentage reported as inhibition, at one concentration (the size of the read-out at that concentration, not a potency): 10%
Compound 4: the middle estimate sits 15 percentage points above what was measured, and the stated range covers the measured number.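

In this assay, replacing furan-3-yl with thiophen-2-yl on the core of compound 3 gives a number 38 percentage points lower from compound 3 to compound 4 (beyond the scatter). Set beside the earlier step, the direction of the change carries over from one core to the other, but its size does not: the same change on two cores in this assay, a number 23 percentage points lower (beyond the scatter) from compound 1 to compound 2 and a number 38 percentage points lower (beyond the scatter) from compound 3 to compound 4, 15 percentage points apart, beyond the scatter of two such steps. Going by these compounds alone, these two pairs show only that the number fell on both cores; they give no general rule for other cores and do not explain why the two steps differ in size.

From the compounds shown here alone, it remains open how a phenyl, furan-2-yl or thiophen-3-yl group would behave on the same saturated ring carbon. Going by these compounds, it is also open whether the step would hold with a carboxylic acid in place of the methoxycarbonyl group.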